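The source may hold more compounds than are shown below. What is called first, only, known or untested is meant among the compounds shown, and "the series" means these compounds.

Going by the values given here, in a physicochemical assay for solubility, read by nephelometry, measured as kinetic solubility, at pH 6.5 (on this read-out lower numbers stand for lower solubility and higher numbers for higher solubility), compound 2 `CC(C)(C)c1cc(C(=O)Nc2ccccc2)n(Cc2ccccc2)n1` gives 1.6 ug/mL as the lowest of the two numbers so far, while compound 1 `CC(=O)NCc1csc(NC(=O)c2cc(C(C)(C)C)nn2Cc2ccccc2)n1` gives 12.5 ug/mL as the higher one, a gap beyond the usual scatter of repeat measurements. Compound 3 `CNCc1csc(NC(=O)c2cc(C(C)(C)C)nn2Cc2ccccc2)n1` has not been measured yet. The structural change from compound 2 to compound 3 is 4-((methylamino)methyl)-1,3-thiazol-2-yl in place of phenyl on an amide-type nitrogen and amounts to 4-((methylamino)methyl)-1,3-thiazol-2-yl in place of phenyl on an amide-type nitrogen. Among the compounds with values here, no measured pair shows a single change of this kind, so its size cannot be read from an earlier step. Within the data shown here, with compound 2 at 1.6 ug/mL as the low mark and compound 1 at 12.5 ug/mL as the only higher number, a rise beyond the scatter is expected. The estimated change is a 22-fold higher number from compound 2 to compound 3 (1.34 log units; beyond the scatter) and it points upward. For compound 3 the expected value is 35 ug/mL within an estimated range of 10 ug/mL to 120 ug/mL in this assay once it is measured.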

Compound 3, solubility: 12.5 ug/mL
For compound 3 the middle estimate is 2.8-fold (0.45 log units) above the measured one; the range from low to high includes it.
By their numbers in this assay, from the lowest: compound 2; then compounds 1 and 3 (each within the scatter of the next).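

Putting 4-((methylamino)methyl)-1,3-thiazol-2-yl in place of phenyl on the amide-type nitrogen gives a 7.8-fold higher number from compound 2 to compound 3 (0.89 log units; beyond the scatter) in this assay and so puts a first measured size on this change. In this assay methyl in place of acetyl on the amine nitrogen gives no change at the digits printed from compound 1 to compound 3 (within the scatter) and the two groups on that nitrogen cannot be told apart on this read-out. With either group on that nitrogen, the number stays well clear of compound 2 at 1.6 ug/mL on this read-out.

Going by these compounds, whether a carboxylic acid or a longer chain in place of the methylamino part would keep the same number remains open. Nothing given here explains these numbers.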